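The compounds below may be only part of what the source reports. "The series", "measured", "known", "first", "only" and "open" are said of these compounds alone.

Testing in an ADME assay on Vero cells (Chlorocebus sabaeus) for cytotoxicity, read by MTT assay, with a stated time of 72 h (a higher number here means a weaker inhibitor, a lower number a stronger inhibitor), covers compound 1 (`COc1ccc2c(c1)[n+]([O-])c(C(=O)NCc1ccccc1)c(C)[n+]2[O-]`), compound 2 (`Cc1c(C(=O)NCc2ccccc2)[n+]([O-])c2cc(F)ccc2[n+]1[O-]`) and compound 3 (`Cc1c(C(=O)NCc2ccccc2)[n+]([O-])c2cc(C(F)(F)F)ccc2[n+]1[O-]`). Compound 1 has "not determined" (no result reported) as its entry and gives no guide. Compound 2 reads > 100 ug/mL and this is a limit of the assay, not a number. Compound 3 reads > 100 ug/mL and this too is only a limit, which is all that can be said of where it stands. Among the compounds with values here, the one measured step is a step that the two limits leave unreadable from compound 2 to compound 3 and it offers no size to carry forward. What remains is the limit of > 100 ug/mL in this assay, at which 2 of the 3 values shown sit, and the expectation rests on that alone.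

Compound 4 (`COc1ccc(CNC(=O)c2c(C)[n+]([O-])c3ccc(C(F)(F)F)cc3[n+]2[O-])cc1`) differs from compound 3 by methoxy in place of hydrogen on an aromatic carbon and the benzyl thus becomes 4-methoxybenzyl. Within the data shown here, no measured step covers this change, so no shift beyond the usual scatter is expected in this assay and another limit is the likeliest report. The expected step is a number no higher from compound 3 to compound 4 (the limit leaves the size open) and it remains an estimate. For compound 4 the estimated value is 100 ug/mL with 50 ug/mL to 200 ug/mL as its expected range.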

Compound 4, half-maximal inhibitory concentration: > 30 ug/mL
Compound 4 gave a limit, no number (the forecaster's own chance of this, stated with the estimate: 70%); the middle value lies beyond the limit too.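

Compound 3 and compound 4 are both reported only as limits, not numbers, so no step can be read between them. The compounds shown leave open what actual number any of them would give in this assay, and whether methoxy in place of hydrogen shifts it at all.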